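The source may report more compounds than this note shows. Statements on the series, on what has been measured and on what is new or still open speak of the compounds shown alone.

In a functional assay on KOPN-8 cells (Homo sapiens) for antiproliferative activity, with a stated time of 72 h (a higher number here means that more compound is needed for the effect, a lower number that less compound is needed), compound 1 `COc1ccc(-c2cc(=O)c3c(OC)cc(OC)cc3n2Cc2ccccc2)cc1` reaches only a limit of the assay, > 17300 nM. Compound 2 `COc1ccc(-c2cc(=O)c3c(OC)cc(OC)cc3n2S(=O)(=O)c2ccc(F)cc2)cc1` likewise gives only a limit, > 65500 nM. Because both values are limits, the step that the two limits leave unreadable from compound 1 to compound 2 cannot be read. Compound 3 `COc1ccc(-c2cc(=O)c3c(OC)cc(OC)cc3n2S(=O)(=O)c2ccc(Cl)cc2)cc1` differs from compound 2 by chloro in place of fluoro on an aromatic carbon. Among the measured compounds shown here, no measured step bears on this change, and the limits give no direction, so the estimated step is a number no higher from compound 2 to compound 3 (the limit leaves the size open), none beyond the scatter. Compound 3 is therefore expected to give about 65500 nM, within 20000 nM to 200000 nM, most likely again as a limit.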

Compound 3, half-maximal effective concentration: > 34400 nM
Compound 3 gave a limit, no number; the forecaster's own chance of this, stated with the estimate: 85%; the middle value does not contradict the limit.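

Among the compounds shown here, compound 1, compound 2 and compound 3 all give only limits in this assay, and no step among them can be read. As far as these compounds go, whether chloro in place of fluoro changes the concentration needed in this assay remains open.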